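The compounds below may be only part of what the source reports. "The series", "measured", "known", "first", "only" and "open" are said of these compounds alone.

Three compounds share one core and differ only in the ring attached to the sulfonyl sulfur. Compound 1 `CCOC(=O)c1oc2ccc(N(Cc3ccccc3)S(=O)(=O)c3cccc(Br)c3)cc2c1C` carries a 3-bromophenyl there; in a functional assay on HCT-116 cells (Homo sapiens) for inhibition, read by MTT assay, with a stated time of 72 h (on this read-out higher numbers stand for weaker inhibition and lower numbers for stronger inhibition), compound 1 gives > 40000 nM, which is a limit of the assay and not a number. Compound 2 `CCOC(=O)c1oc2ccc(N(Cc3ccccc3)S(=O)(=O)c3ccccc3Br)cc2c1C` carries a 2-bromophenyl; in this assay compound 2 gives > 40000 nM, again a limit. Compound 3 `CCOC(=O)c1oc2ccc(N(Cc3ccccc3)S(=O)(=O)c3ccc(F)cc3)cc2c1C` carries a 4-fluorophenyl, and in this assay compound 3 gives 5820 nM, the only number shown. Compound 1 and compound 2 both sit at the limit (the limit of > 40000 nM in this assay, at which 2 of the 3 values shown sit). The step from compound 1 to compound 3 reads an at least 6.8-fold lower number from compound 1 to compound 3 (0.83 log units; beyond the scatter), and the step from compound 2 to compound 3 reads an at least 6.8-fold lower number from compound 2 to compound 3 (0.83 log units; beyond the scatter). Compound 4 `CCOC(=O)c1oc2ccc(N(Cc3ccccc3)S(=O)(=O)c3ccccc3)cc2c1C` has not been measured; the change is hydrogen in place of fluoro on an aromatic carbon. Both measured steps show that the substituent on this ring can move the number beyond the scatter, but neither removes a substituent altogether, so they do not fix the direction. Removing the fluoro is expected to weaken inhibition somewhat, an expected step of a 2.1-fold higher number from compound 3 to compound 4 (0.31 log units; beyond the scatter). Compound 4 is therefore estimated at 12000 nM, within the range 3000 nM to 40000 nM.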

Compound 4, half-maximal inhibitory concentration: > 40000 nM
Compound 4: a limit, no number; the forecaster's own chance of this, stated with the estimate: 25%; middle value at least 3.3-fold (0.52 log units) away from the limit.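

Taking away a single fluoro atom gives an at least 6.8-fold higher number from compound 3 to compound 4 (0.83 log units; beyond the scatter), so the direction that the earlier steps left unsettled is now fixed at this position: in this assay, the 4-fluorophenyl of compound 3 gives stronger inhibition than the plain phenyl of compound 4. Compound 3 is now the only one of the four with a number, and compound 4 joins the two bromophenyl compounds at the limit: the limit of > 40000 nM in this assay, at which 3 of the 4 values shown sit. The steps from compound 1 and from compound 2 to compound 4 cannot be read, as both ends of each are limits.

As far as these compounds go, how large the fluoro step really is stays open, as compound 4 has only a limit. Also open, from the compounds shown here alone, is whether this position needs fluoro specifically, or whether another group, such as the chloro of a 4-chlorophenyl or the methoxy of a 4-methoxyphenyl, would also give a measurable number.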